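The compounds below may be only part of what the source reports. "The series", "measured", "known", "first", "only" and "open" are said of these compounds alone.

Measured in a functional assay on MDA-MB-231 cells (Homo sapiens) for antiproliferative activity, read by MTT assay, with a stated time of 72 h; on this read-out lower numbers stand for stronger inhibition and higher numbers for weaker inhibition:
- compound 1 `CC1=CC[C@H]2[C@H](CC[C@]2(C)O)C(C)(C)[C@@H]1CC[C@H]1[C@]2(C)CC[C@H](OC(=O)c3ccc(C)cc3)C(C)(C)O[C@H]2CC[C@@]1(C)O`: 33400 nM
- compound 2 `CC1=CC[C@H]2[C@H](CC[C@]2(C)O)C(C)(C)[C@@H]1CC[C@H]1[C@]2(C)CC[C@H](OC(=O)c3ccccc3F)C(C)(C)O[C@H]2CC[C@@]1(C)O`: 28700 nM

Compound 2, at 28700 nM, cannot be separated from compound 1, at 33400 nM: the two values lie within the scatter of each other. Compound 3 `CC1=CC[C@H]2[C@H](CC[C@]2(C)O)C(C)(C)[C@@H]1CC[C@H]1[C@]2(C)CC[C@H](OC(=O)c3ccc(C(F)(F)F)c(F)c3)C(C)(C)O[C@H]2CC[C@@]1(C)O` has 3-fluoro-4-(trifluoromethyl)phenyl in place of 2-fluorophenyl on a carbonyl carbon. Among the compounds with values here, one measured step bears on this change, since it also exchanges the group on that carbonyl carbon: a 1.2-fold lower number from compound 1 to compound 2 (0.07 log units; within the scatter). That step stays within the scatter, but it is a single exchange between two other groups, so the support is thin. No shift beyond the scatter is therefore expected in this assay, and no direction is favoured. The expected step is a 1.1-fold lower number from compound 2 to compound 3 (0.03 log units; within the scatter). For compound 3 the estimated value is 27000 nM, with an expected range of 12000 nM to 55000 nM.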

Compound 3, half-maximal inhibitory concentration: 22200 nM
Estimate against measurement, compound 3: 1.2-fold (0.09 log units) above, within the range that was stated.
By their numbers in this assay, from the lowest: compounds 3, 2 and 1 (each within the scatter of the next).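

In this assay a heavier exchange on this carbonyl carbon, with 11 heavy atoms entering and 7 leaving, gives a 1.3-fold lower number from compound 2 to compound 3 (0.11 log units; within the scatter) and stays inside the scatter. The comparison with the 4-methylphenyl compound gives a 1.5-fold lower number from compound 1 to compound 3 (0.18 log units; within the scatter) and also stays inside it, so three differently substituted phenyl groups now cannot be told apart in this assay. Nothing available bears on why these groups read alike.

The compounds shown carry only substituted phenyl groups on this carbonyl carbon, so it remains open whether an amine, a carboxylic acid or a longer alkyl chain there would move the number beyond the scatter. Also open, on these data alone, is whether any change elsewhere on the shared core would do so.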